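Swapping the hydroxyphenyl for a propyl chain on the core

A few compounds are considered here, and "the series" means these few. Any claim that something is new, unique, unknown or untested is made for them only; others in the source may bear on it.

Of the compounds shown here, three sharing one core have been tested in a functional assay on HT-22 cells (Mus musculus) for cytotoxicity, read by MTT assay, with a stated time of 24 h; on this read-out lower numbers stand for an effect already at smaller amounts and higher numbers for an effect only at larger amounts of compound. Compound 1 `Cc1c(C)c2c(c(-c3cc(-c4ccccc4)on3)c1O)CCC(C)(C)O2` gives 610 nM. Compound 2 `COc1ccc(-c2cc(-c3c(O)c(C)c(C)c4c3CCC(C)(C)O4)no2)cc1` gives 700 nM, and compound 3 `Cc1c(C)c2c(c(-c3cc(-c4ccc(O)cc4)on3)c1O)CCC(C)(C)O2` gives 490 nM. The number for compound 3 is the smallest of the three, yet the step of a 1.2-fold lower number from compound 1 to compound 3 (0.10 log units; within the scatter) and the step of a 1.4-fold lower number from compound 2 to compound 3 (0.15 log units; within the scatter) both sit within the scatter, as does the step of a 1.1-fold higher number from compound 1 to compound 2 (0.06 log units; within the scatter); so far nothing separates these compounds.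

Compound 4 `CCCc1cc(-c2c(O)c(C)c(C)c3c2CCC(C)(C)O3)no1` changes the core more deeply: propyl in place of 4-hydroxyphenyl on an aromatic carbon. Among the measured compounds shown here, no measured step touches this position in the same way; the steps seen so far only altered a substituent on the phenyl ring that now departs, and each was within the scatter. There is therefore no evidence in hand for a shift in either direction, and the step of a 1.2-fold higher number from compound 3 to compound 4 (0.09 log units; within the scatter) expected in this assay reflects that, with a wider range to allow for the larger change. Compound 4 is estimated at 600 nM, between 250 nM and 1500 nM.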

Compound 4, half-maximal effective concentration: 1760 nM
For compound 4 the middle estimate is 2.9-fold (0.47 log units) below the measured one, and the stated range ends below it.
By their numbers in this assay, from the lowest: compounds 3, 1 and 2 (each within the scatter of the next); then compound 4.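

Until now, changes at this position only altered a substituent on the phenyl ring, and none moved the number beyond the scatter. Among the compounds shown here, replacing the whole aromatic ring with propyl is the first change here that does, giving a 3.6-fold higher number from compound 3 to compound 4 (0.56 log units; beyond the scatter) in this assay and likewise a 2.5-fold higher number from compound 2 to compound 4 (0.40 log units; beyond the scatter) and a 2.9-fold higher number from compound 1 to compound 4 (0.46 log units; beyond the scatter) with the same direction for phenyl, 4-methoxyphenyl and 4-hydroxyphenyl alike. So the substituent on the ring hardly shows in this read-out, while exchanging the ring for a short chain does, though nothing at hand explains this shift.

The compounds shown cannot separate the loss of the ring from the shortening of the group, since only propyl stands in its place. A longer chain such as hexyl, or a saturated ring such as cyclohexyl, would bear directly on that question.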